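The compounds below may be only part of what the source reports. "The series", "measured", "known", "first", "only" and "open" are said of these compounds alone.

Measured compounds in an ADME assay on microsomes from liver (Mus musculus) for metabolic stability, read by LC-MS, using NADPH, with a stated time of 60 min, tested at 1 uM, in the presence of a further agent that is not named here; on this read-out higher numbers stand for fast clearance and lower numbers for slow clearance:
compound 1, `Clc1ccc2nc(-c3ccccn3)c(Nc3ccc4c(c3)OCCO4)n2c1`
compound 2, `COc1ccnc(-c2nc3ccccn3c2NC2CCCC2)c1`
compound 3, `COc1ccc(-c2nc3ccccn3c2Nc2ccc(F)cc2)nc1`

Compound 1 gives a limit of the assay in this assay, reported as > 1000 uL/min, which is a limit and not a number (the limit of > 1000 uL/min in this assay, at which 1 of the 3 values shown sits). Compound 2 gives 932 uL/min in this assay. Compound 3 gives 126 uL/min in this assay, and it stands lowest of the two numbers on record; its nearest neighbour is compound 2, whose value is beyond the scatter higher than that of compound 3. No pair among these three compounds differs in only one place, so no measured step is available to lean on.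

The compound that has not yet been measured is compound 4, `COc1ccnc(-c2nc3ccccn3c2Nc2ccc(F)cc2)c1`. It differs from compound 3 in one place (4-methoxypyridin-2-yl in place of 5-methoxypyridin-2-yl on an aromatic carbon). The two compounds hold the same atoms joined differently, with the methoxy group moved within the pyridine ring. Going by the values given here, no measured pair shows what such a move does in this assay. The step of a 1.4-fold higher number from compound 3 to compound 4 (0.15 log units; within the scatter) is expected to be small, possibly none beyond the scatter, with a lean toward a somewhat higher number. For compound 4 the estimate in this assay is 180 uL/min, with a range from 60 uL/min to 500 uL/min.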

Compound 4, intrinsic clearance in a liver preparation (reported as CLH), per the amount of preparation that the assay uses: > 1000 uL/min
Compound 4: a limit, no number; the forecaster's own chance of this, stated with the estimate: 5%; at least 5.5-fold (0.74 log units) between middle value and limit.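

In this assay, putting 4-methoxypyridin-2-yl in place of 5-methoxypyridin-2-yl on the aromatic carbon gives an at least 7.9-fold higher number from compound 3 to compound 4 (0.89 log units; beyond the scatter), which shows that at this position the place of the methoxy group within the pyridine ring can on its own, with the same atoms, separate a moderate clearance from a very fast one. With 4-methoxypyridin-2-yl held constant, 4-fluorophenyl in place of cyclopentyl on the nitrogen gives an at least 1.0-fold higher number from compound 2 to compound 4 (0.03 log units; that floor lies within the scatter), so no order between these two compounds can be read from that step. The value of compound 4 is a limit and not a number, so the full size of both steps stays unknown, and it is the second such value in the set: the limit of > 1000 uL/min in this assay, at which 2 of the 4 values shown sit.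

From the compounds shown here alone, it remains open whether 5-methoxypyridin-2-yl would lower the clearance in the same way with cyclopentyl on the nitrogen, or whether that effect holds only alongside 4-fluorophenyl. Also open, going by these compounds, is how an unsubstituted pyridin-2-yl group, or an ethoxy or dimethylamino group in place of the methoxy group, would read at this position in this assay.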